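Indole for Methylthiophene on a Chlorophenyl Enone Sulfone

A few compounds are considered here, and "the series" means these few. Any claim that something is new, unique, unknown or untested is made for them only; others in the source may bear on it.

Compound 3 `Cc1ccsc1/C=C(\C(=O)c1ccc(Cl)cc1)S(=O)(=O)Cc1ccc(F)cc1` gives the lowest number of the three measured compounds in a functional assay on DU-145 cells (Homo sapiens) for inhibition, read by trypan blue exclusion, with a stated time of 96 h (a higher number here means a weaker inhibitor of growth, a lower number a stronger inhibitor of growth), at 10000 nM. Compound 1 `Cc1ccc(CS(=O)(=O)/C(=C/c2c[nH]c3ccccc23)C(=O)c2ccc(Cl)cc2)cc1` gives 25000 nM in this assay, and compound 2 `Cc1ccsc1/C=C(\C(=O)c1ccc(Cl)cc1)S(=O)(=O)Cc1ccc(Cl)cc1` gives 25000 nM. Among the compounds with values here, the only single-change step measured so far, a 2.5-fold lower number from compound 2 to compound 3 (0.40 log units; beyond the scatter), swaps one halogen for another on the benzyl part and does not touch the group that changes now.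

Compound 4 `O=C(/C(=C\c1c[nH]c2ccccc12)S(=O)(=O)Cc1ccc(F)cc1)c1ccc(Cl)cc1` keeps the fluorine-bearing benzyl sulfone of compound 3 and carries 1H-indol-3-yl in place of 3-methylthiophen-2-yl on a double-bonded chain carbon bound to a double-bonded chain carbon. Within the data shown here, no measured step isolates this exchange. Compound 1, which carries the 1H-indol-3-yl group but a different benzyl substituent, gives a weaker number than compound 3, yet it differs from compound 3 in two places, so its value gives only a rough hint. On that basis compound 4 is expected to show a small step toward a higher number, a 1.6-fold higher number from compound 3 to compound 4 (0.20 log units; within the scatter), and its growth-inhibition value in this assay is estimated at 16000 nM, within a range of 6000 nM to 40000 nM.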

Compound 4, concentration for 50% growth inhibition: 50000 nM
Estimate against measurement, compound 4: 3.1-fold (0.49 log units) below, outside the stated range (above it).
By their numbers in this assay, from the lowest: compound 3; then compounds 1, 2 and 4 (each within the scatter of the next).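

In this assay, the direct exchange of 3-methylthiophen-2-yl for 1H-indol-3-yl gives a 5.0-fold higher number from compound 3 to compound 4 (0.70 log units; beyond the scatter) and so shows that, with the fluorine-bearing benzyl sulfone held fixed, this position on the double-bonded chain carbon affects growth inhibition. With 1H-indol-3-yl in place, the benzyl exchange gives a 2.0-fold higher number from compound 1 to compound 4 (0.30 log units; within the scatter) and so does not separate this pair of compounds. Nothing measured here explains the change at the double-bonded chain carbon.

The 1H-indol-3-yl group brings its extra six-membered ring and its hydrogen-bond donor together, so the compounds shown cannot tell which of the two goes with the higher number. From the compounds shown here alone, a 1-methylindol-3-yl or plain phenyl group at this place could help separate those features, and whether the step holds with other benzyl substituents remains open.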